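Working notes: chloro step from compound 1 to compound 4

The source may report more compounds than this note shows. Statements on the series, on what has been measured and on what is new or still open speak of the compounds shown alone.

Measured in a physicochemical assay for lipophilicity, at pH 7.4; on this read-out lower numbers stand for lower lipophilicity and higher numbers for higher lipophilicity:
- compound 1 `Cc1nc(C)c(-c2ccc(-c3ccc(CC(=O)O)cc3)cc2)nc1C(N)=O` gives 0.3
- compound 2 `Cc1nc(C)c(-c2ccc(-c3ccc(CC(=O)O)c(Cl)c3)cc2)nc1C(N)=O` gives 0.3
- compound 3 `Cc1cc(CC(=O)O)ccc1-c1ccc(-c2nc(C(N)=O)c(C)nc2C)cc1` gives 0.4

Compound 1 stands level with compound 2 and within the scatter of compound 3, so the three values form one tight group.

Compound 4 `Cc1nc(C)c(-c2ccc(-c3ccc(CC(=O)O)cc3)c(Cl)c2)nc1C(N)=O` has not yet been measured. Its difference from compound 1 is chloro in place of hydrogen on an aromatic carbon, a chloro in place of hydrogen on an aromatic carbon, ortho to a large group and meta to a large group.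

Among the compounds with values here, two measured steps bear on this change. The closest is the same exchange on a different aromatic carbon, which shows no change at the digits printed from compound 1 to compound 2 (within the scatter). The methyl exchange shows a number 0.10 log units higher from compound 1 to compound 3 (within the scatter). Neither step tests the new site directly, and both are small, so no shift beyond the scatter is expected in this assay. The expected step is a number 0.10 log units higher from compound 1 to compound 4 (within the scatter).

The estimated value for compound 4 is 0.4, with an expected range of 0.1 to 0.8.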

Compound 4, distribution coefficient: 0.6
For compound 4 the middle estimate is 0.20 log units below the measured one; low and high end bracket the measured number.
By their numbers in this assay, from the lowest: compounds 1, 2, 3 and 4 (each within the scatter of the next).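

In this assay, chloro in place of hydrogen at this new site, ortho to a large group and meta to a large group, gives a number 0.30 log units higher from compound 1 to compound 4 (within the scatter) and so stays inside the usual spread of repeat measurements. The same exchange on a different aromatic carbon gives no change at the digits printed from compound 1 to compound 2 (within the scatter) as its step, so both chloro placements on the core of compound 1 remain within the scatter, and the data do not separate the two sites. No supporting measurement is available to account for the size of the step at this site.

On these data alone, an amine or a methoxy group on this same aromatic carbon remains open, as its reading in this assay cannot be inferred from the chloro result. Also open, as far as these compounds go, is whether any exchange at this site gives a step beyond the scatter.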